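The source may report more compounds than this note shows. Statements on the series, on what has been measured and on what is new or still open speak of the compounds shown alone.

Measured so far:
- compound 1 `Cn1c(=O)c(S(=O)(=O)c2ccc(F)cc2)cc2cnc(Nc3cccc4[nH]ccc34)nc21`: 750 nM
- compound 2 `Cn1c(=O)c(S(=O)(=O)c2ccc([N+](=O)[O-])cc2F)cc2cnc(Nc3ccc4[nH]ccc4c3)nc21`: 200 nM
- compound 3 `Cn1ccc2cc(Nc3ncc4cc(S(=O)(=O)c5ccc(Cl)cc5Cl)c(=O)n(C)c4n3)ccc21`: 750 nM

These three compounds were tested in a functional assay on K562 cells (Homo sapiens) for inhibition, read by trypan blue exclusion, with a stated time of 72 h; a higher number here means a weaker inhibitor, a lower number a stronger inhibitor. Compound 2 gives the lowest number of the three; compound 1 and compound 3 each sit well above it, and both gaps are beyond the usual scatter, so compound 2 is the strongest inhibitor among the measured compounds.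

Compound 4 `Cn1c(=O)c(S(=O)(=O)c2ccc(Br)cc2)cc2cnc(Nc3ccc4[nH]ccc4c3)nc21` has not yet been measured. It keeps the shared core and the same indole attachment as compound 2 and changes only the aryl group on the sulfonyl: 4-bromophenyl in place of 2-fluoro-4-nitrophenyl on a sulfonyl sulfur. Going by the values given here, no directly comparable pair has been measured, so the size of this step is uncertain. The two compounds that carry a simpler halogenated aryl group on the sulfonyl, compound 1 and compound 3, both give higher numbers than compound 2, though they also differ elsewhere. A modest loss of potency is therefore expected rather than a gain. Compound 4 is estimated at 500 nM, with a range from 150 nM to 1500 nM, which means an expected step of a 2.5-fold higher number from compound 2 to compound 4 (0.40 log units; beyond the scatter).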

Compound 4, half-maximal inhibitory concentration: 5000 nM
The estimate for compound 4 lay 10-fold (1.00 log units) below the measured number, and the stated range ends below it.
By their numbers in this assay, from the lowest: compound 2; then compounds 1 and 3 (each within the scatter of the next); then compound 4.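

In this assay, with the shared core and the indole attachment unchanged, 4-bromophenyl in place of 2-fluoro-4-nitrophenyl on a sulfonyl sulfur gives a 25-fold higher number from compound 2 to compound 4 (1.40 log units; beyond the scatter) and is a large step. This is the only pair shown that differs in one place, and it shows what the earlier compounds could not: the aryl group on the sulfonyl alone can shift the number this far. No measurement shown explains this loss of potency.

The change removes the nitro group and the fluorine and adds the bromine all at once, leaving open which of these differences accounts for the step. Also open, from the compounds shown here alone, is how an aryl group carrying a nitrile or an amine would compare at this position in this assay, or whether a phenyl group with only the fluorine or only the nitro group would keep the lower number.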